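This account rests on a few compounds, and the source may have more. Where it says the series, first, only, none or still open, it means among the compounds named here.

Working notes on the series. Compound 1 `CCCCNc1nc(N)nc2ccc(CCc3ccc(N(C)C)cc3)cc12` and compound 2 `CCCCNc1nc(N)nc2cccc(C)c12` share the core; in an ADME assay on HEK293 cells for agonist activity at Toll-like receptor 8 (Homo sapiens), read by a luciferase reporter, with a stated time of 6 h (on this read-out higher numbers stand for an effect only at larger amounts of compound and lower numbers for an effect already at smaller amounts), compound 1 gives 0.5 uM, and compound 2 gives 0.3 uM, the lowest of the two numbers, with compound 1 the nearest and within the scatter of it. Going by the values given here, no step between measured compounds differing in one place is known. Compound 3 `CCCCNc1nc(N)nc2cccc(OCc3cccnc3)c12` carries (pyridin-3-yl)methoxy in place of methyl on an aromatic carbon. In this assay a step of no change at the digits printed from compound 2 to compound 3 (within the scatter) is expected, none beyond the scatter, since the two values available show no clear trend. Compound 3 is expected to give 0.3 uM, with a range from 0.06 uM to 1.5 uM.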

Compound 3, minimum effective concentration: 0.53 uM
Beside the measured number, compound 3's estimate is 1.8-fold (0.25 log units) below it; the measured number falls inside the stated range.
By their numbers in this assay, from the lowest: compounds 2, 1 and 3 (each within the scatter of the next).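

Placing (pyridin-3-yl)methoxy in place of methyl on this aromatic carbon gives a 1.8-fold higher number from compound 2 to compound 3 (0.25 log units; within the scatter) in this assay, the first step read at this position. The position therefore carries the larger group, with its six-membered aromatic ring, with no change beyond the scatter. Nothing available bears on why this is so.

As far as these compounds go, whether a plain methoxy or a benzyloxy group would behave the same way remains open. So does the outcome with an amine or a carboxylic acid on this carbon.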